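Swapping chloro for methyl on a fused aromatic ring

The source may report more compounds than this note shows. Statements on the series, on what has been measured and on what is new or still open speak of the compounds shown alone.

Of the compounds shown here, three sharing one core have been tested in an assay on cells (Ventricular myocyte) for inhibition of potassium voltage-gated channel subfamily KQT member 1 (Cavia porcellus), read by patch clamp; a higher number here means a weaker inhibitor, a lower number a stronger inhibitor. Compound 1 `COc1ccc2c(c1)/C(=N/N1CC(=O)N(CCCCN3CCCCC3)C1=O)CCO2` gives 22000 nM. Compound 2 `CCOc1ccc2c(c1)/C(=N/N1CC(=O)N(CCCCN3CCCCC3)C1=O)CCO2` gives 1040 nM. Compound 3 `O=C1CN(/N=C2\CCOc3ccc(Cl)cc32)C(=O)N1CCCCN1CCCCC1` gives 61000 nM, the highest of the three numbers, standing a modest distance from compound 1 and far from compound 2.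

Compound 4 `Cc1ccc2c(c1)/C(=N/N1CC(=O)N(CCCCN3CCCCC3)C1=O)CCO2` has not been measured. It differs from compound 3 in one place: methyl in place of chloro on an aromatic carbon, on an aromatic carbon of a six-membered aromatic ring of carbon only, part of a fused system of two rings.

For the measured compounds named here, two measured steps touch this position. Replacing methoxy with chloro gave a 2.8-fold higher number from compound 1 to compound 3 (0.44 log units; beyond the scatter), and replacing ethoxy with chloro gave a 59-fold higher number from compound 2 to compound 3 (1.77 log units; beyond the scatter). Both show that this position matters, and that the group there can shift the number widely, while a methyl group has not been tried. A change from one small group to another is expected to shift the number less than the large step seen with ethoxy, perhaps only within the usual scatter.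

Compound 4 is therefore estimated at 30000 nM, with a range from 8000 nM to 120000 nM, an expected step of a 2.0-fold lower number from compound 3 to compound 4 (0.31 log units; beyond the scatter).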

Compound 4, half-maximal inhibitory concentration: 18900 nM
Beside the measured number, compound 4's estimate is 1.6-fold (0.20 log units) above it, within the range that was stated.
By their numbers in this assay, from the lowest: compound 2; then compounds 4 and 1 (each within the scatter of the next); then compound 3.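

In this assay, methyl in place of chloro on this aromatic carbon gives a 3.2-fold lower number from compound 3 to compound 4 (0.51 log units; beyond the scatter), so even an exchange of one single heavy atom for another moves the number beyond the scatter. Methyl in place of methoxy gives a 1.2-fold lower number from compound 1 to compound 4 (0.07 log units; within the scatter), which lies within the scatter, so methyl and methoxy cannot be told apart at this position, and chloro, not methoxy, now looks like the group that stands a little apart from these two. Methyl in place of ethoxy gives an 18-fold higher number from compound 2 to compound 4 (1.26 log units; beyond the scatter), which shows that the low number of compound 2 is not shared by the other small group tried here, and that of the four groups at this position, only ethoxy stands far from the rest.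

On these data alone, whether a longer chain on the oxygen, such as propoxy or butoxy, would lower the number further or raise it again stays open, as does how an amine or a carboxylic acid would read at this position. No measurement among these data explains any of these steps.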